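Replacing a methoxyphenyl sulfone with a tolyl sulfone

The source may report more compounds than this note shows. Statements on the series, on what has been measured and on what is new or still open speak of the compounds shown alone.

Of the compounds shown here, three sharing one core have been measured in a functional assay on A549 cells (Homo sapiens) for cytotoxicity, read by MTT assay, with a stated time of 72 h; on this read-out higher numbers stand for weaker inhibition and lower numbers for stronger inhibition. Compound 1, `COc1cc2c(Oc3ccc(NC(=O)c4cn(-c5cc(C)ccc5C)cn4)cc3F)ccnc2cc1OCCCN1CCN(C)CC1`, gives 350 nM in this assay. Compound 2, `COc1cc2c(Oc3ccc(NC(=O)c4cn(-c5ccccc5OC)cn4)cc3F)ccnc2cc1OCCCN1CCCCC1`, gives 120 nM. Compound 3, `COc1cc2c(Oc3ccc(NC(=O)/C=C/S(=O)(=O)c4ccccc4OC)cc3F)ccnc2cc1OCCCN1CCN(C)CC1`, gives 320 nM. Among these three numbers compound 3 holds the second highest place: its value and that of compound 1 lie within the usual scatter of each other, so no difference between them can be claimed, while compound 2 sits at a lower number, beyond the scatter.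

Compound 4, `COc1cc2c(Oc3ccc(NC(=O)/C=C/S(=O)(=O)c4ccc(C)cc4)cc3F)ccnc2cc1OCCCN1CCN(C)CC1`, has not yet been measured. It differs from compound 3 in one place: 4-methylphenyl in place of 2-methoxyphenyl on a sulfonyl sulfur. Both the group that leaves and the group that enters are a single six-membered aromatic ring attached to the sulfonyl sulfur, with the substituent on that ring changed. Among the measured compounds shown here, no measured pair in this set shows what such a change does, so the expectation rests on the closeness of compounds 1 and 3 alone. The step expected from compound 3 to compound 4 in this assay is a 1.1-fold higher number from compound 3 to compound 4 (0.04 log units; within the scatter), that is, none beyond the scatter in either direction. Compound 4 is therefore estimated at 350 nM, within a range from 120 nM to 1000 nM.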

Compound 4, half-maximal inhibitory concentration: 1510 nM
Estimate against measurement, compound 4: 4.3-fold (0.63 log units) below; the measured number lies above the stated range.
By their numbers in this assay, from the lowest: compound 2; then compounds 3 and 1 (each within the scatter of the next); then compound 4.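

In this assay, the group on the sulfonyl sulfur proves to matter: 4-methylphenyl in place of 2-methoxyphenyl gives a 4.7-fold higher number from compound 3 to compound 4 (0.67 log units; beyond the scatter), a step beyond the scatter. Among the compounds shown here, this is the first comparison in the set between compounds that differ in one place, and it shows that two groups which are each a single six-membered aromatic ring of carbon, differing only in the substituent on that ring, need not give the same result at this position. Nothing measured alongside these compounds explains the step.

The change alters both the kind of substituent and where it sits on the ring, so these compounds cannot show whether the methoxy-to-methyl swap, the new location or both together account for the higher number. A 4-methoxyphenyl or a 2-methylphenyl on the same sulfonyl sulfur would separate those two changes, and a plain phenyl would show what the ring gives with no substituent at all.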